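This account rests on a few compounds, and the source may have more. Where it says the series, first, only, none or still open, it means among the compounds named here.

Measured compounds:
compound 1 `O=C(Nc1ccc(OC(F)(F)F)cc1)N1CCOC2(CCN(C(=O)c3cc(Cl)ccn3)CC2)C1` gives 89 ug/mL in an ADME assay for solubility, in simulated intestinal fluid; a higher number here means a more soluble compound, a lower number a less soluble compound;
compound 2 `N#Cc1ccc(C(=O)N2CCC3(CC2)CN(C(=O)Nc2ccc(C(F)(F)F)cc2)CCO3)cc1` gives 82 ug/mL;
compound 3 `O=C1Cc2cc(C(=O)N3CCC4(CC3)CN(C(=O)Nc3ccc(OC(F)(F)F)cc3)CCO4)ccc2N1` gives 93 ug/mL.

The three values lie within the scatter of one another, so compound 2 is not set apart from compound 1 or compound 3 in this assay. Compound 4 `O=C(Nc1ccc(C(F)(F)F)cc1)N1CCOC2(CCN(C(=O)c3ccccc3Cl)CC2)C1` has not yet been measured. It differs from compound 2 by 2-chlorophenyl in place of 4-cyanophenyl on a carbonyl carbon. Within the data shown here, the one measured step at this same place, a 1.0-fold higher number from compound 1 to compound 3 (0.02 log units; within the scatter), swapped the group on the carbonyl carbon and left the number where it was. Among the measured compounds shown here, no measured pair shows a change at this carbonyl carbon that went beyond the scatter, so a similar outcome is expected for compound 4, with a 1.0-fold lower number from compound 2 to compound 4 (0.01 log units; within the scatter) expected to stay within the scatter. Compound 4 is therefore estimated at 80 ug/mL, with a likely range from 40 ug/mL to 160 ug/mL.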

Compound 4, solubility: 12 ug/mL
Compound 4: the middle estimate sits 6.7-fold (0.82 log units) above what was measured; the measured number lies below the stated range.
By their numbers in this assay, from the lowest: compound 4; then compounds 2, 1 and 3 (each within the scatter of the next).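

In this assay, among these compounds, the group on this carbonyl carbon proves able to move the number beyond the scatter: 2-chlorophenyl in place of 4-cyanophenyl gives a 6.8-fold lower number from compound 2 to compound 4 (0.83 log units; beyond the scatter), whereas the only earlier step here stayed within it (a 1.0-fold higher number from compound 1 to compound 3 (0.02 log units; within the scatter)). The position is therefore not indifferent to the group it carries. Nothing at hand gives a reason for this drop. The compounds shown leave open whether the drop goes with the arrival of 2-chlorophenyl or the departure of 4-cyanophenyl. They also leave open where an unsubstituted phenyl, or a phenyl carrying an amine, would fall at this carbonyl carbon.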